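Branching the Ester Chain: From Compound 3 to Compound 4

The compounds below may be only part of what the source reports. "The series", "measured", "known", "first", "only" and "open" are said of these compounds alone.

Of the compounds shown here, three sharing one core have been measured in a functional assay on HT-1080 cells (Homo sapiens), read by transwell migration, with a stated time of 24 h, tested at 1 uM; on this read-out lower numbers stand for a stronger effect and higher numbers for a weaker effect at the one concentration tested. Compound 1 `CC(=O)OCc1ccc2oc(=O)c(C(=O)Sc3ccccc3)cc2c1` gives 83.5%. Compound 2 `CCC(=O)OCc1ccc2oc(=O)c(C(=O)Oc3cccc(Br)c3)cc2c1` gives 40.2%, and compound 3 `CCCC(=O)OCc1ccc2oc(=O)c(C(=O)Oc3cccc(Br)c3)cc2c1` gives 50.5%. Compound 3 therefore holds the second highest of the three numbers, standing close to compound 2 and far from compound 1. Only one pair of these compounds differs in a single place, and that pair reads a number 10.3 percentage points higher from compound 2 to compound 3 (beyond the scatter), a change that added one carbon to a saturated chain.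

Compound 4 `CC(C)C(=O)OCc1ccc2oc(=O)c(C(=O)Oc3cccc(Br)c3)cc2c1` has not yet been measured. It differs from compound 3 in one place: isopropyl in place of propyl on a carbonyl carbon. Here the two structures hold the same atoms joined differently, so nothing is added or removed; the chain is merely rearranged. The measured step bears on this only loosely, since it concerned growing the chain, not rearranging it, and it was modest. A step smaller than that one, and most likely within the scatter, is expected in this assay, with no clear direction. The number for compound 4 in this assay is expected to be about 48%, most likely between 33% and 63%, which would mean an estimated step of a number 2.5 percentage points lower from compound 3 to compound 4 (within the scatter).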

Compound 4, a percentage reported as activity, at one concentration (the size of the read-out at that concentration, not a potency): 37.8%
Compound 4: the middle estimate sits 10.2 percentage points above what was measured; measured number inside the range.
By their numbers in this assay, from the lowest: compounds 4 and 2 (each within the scatter of the next); then compound 3; then compound 1.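

In this assay, joining the same carbons differently, with nothing added or removed, gives a number 12.7 percentage points lower from compound 3 to compound 4 (beyond the scatter) and so shows that on this carbonyl carbon the arrangement of the chain matters as well as its carbon count. The two routes from compound 2 also part ways: a methyl on the saturated chain carbon bound to the carbonyl carbon gives a number 2.4 percentage points lower from compound 2 to compound 4 (within the scatter) in this comparison, while a methyl two bonds along the chain from the carbonyl carbon gave a number 10.3 percentage points higher from compound 2 to compound 3 (beyond the scatter) in the earlier one, so the same added carbon reads differently depending on where it sits. (The data shown offer no measured explanation for either result).

On these data alone, what remains open is whether a tert-butyl group, a cyclopropyl ring or a longer chain on this carbonyl carbon would read like compound 4 or like compound 3. Also open, as far as these compounds go, is whether these differences would hold at other concentrations, since each number here comes from a single concentration and says nothing about potency.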